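Swapping methyl for bromo in compound 1

The source may report more compounds than this note shows. Statements on the series, on what has been measured and on what is new or still open speak of the compounds shown alone.

Measured in a functional assay on SW-620 cells (Homo sapiens) for inhibition, read by MTT assay; on this read-out lower numbers stand for stronger inhibition and higher numbers for weaker inhibition:
- Compound 1 `Cc1ccc(-c2nnc(NC(=O)CCCCCCC(=O)NO)s2)o1`: 880 nM
- Compound 2 `Cc1ccc2c(c1)/C(=N\O)C(=O)N2CCCC(=O)NO`: 490 nM

These two values lie within the usual scatter of each other, so compound 1 stands level with compound 2 and the pair cannot be ranked. Compound 3 `O=C(CCCCCCC(=O)Nc1nnc(-c2ccc(Br)o2)s1)NO` has not yet been measured. It is compound 1 with bromo in place of methyl on an aromatic carbon, so 5-methylfuran-2-yl becomes 5-bromofuran-2-yl (bromo in place of methyl on an aromatic carbon). The rest of the molecule stays the same.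

Among the measured compounds shown here, no two measured compounds differ in just one place, so the data offer no direct guide to the effect of this swap in this assay. The only sensible starting point is compound 1 at 880 nM, and with so little evidence no direction can be favoured. The expected size of a 1.3-fold lower number from compound 1 to compound 3 (0.10 log units; within the scatter) is therefore nothing beyond the scatter. Compound 3 is estimated at 700 nM, with an expected range from 250 nM to 2000 nM.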

Compound 3, half-maximal inhibitory concentration: 880 nM
Compound 3: the middle estimate sits 1.3-fold (0.10 log units) below what was measured, within the range that was stated.
By their numbers in this assay, from the lowest: compounds 2, 1 and 3 (each within the scatter of the next).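

In this assay, among the compounds shown here, going from 5-methylfuran-2-yl to 5-bromofuran-2-yl gives no change at the digits printed from compound 1 to compound 3 (within the scatter), and this is the first direct reading of any single change. At this aromatic carbon, next to the ring oxygen, methyl and bromo cannot be told apart on this read-out, so the number for this pair gives no reason to prefer either group. The finding is limited to these two groups on this one core, and nothing measured here offers an explanation for the match.

On these data alone, whether this position stays as undemanding for groups of a different kind remains open, since an amine, a carboxylic acid or a phenyl ring on the same carbon could give a clearly different number. For the compounds shown here, it is also open whether methyl and bromo would still read alike on a core with a longer chain than the one in compound 1, or in cells other than those of this assay.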